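A few compounds are considered here, and "the series" means these few. Any claim that something is new, unique, unknown or untested is made for them only; others in the source may bear on it.

Compound 1 `CC(C)C(=O)N1CC2CC(C1)N2`: 45%
Compound 2 `O=C(C1CCCC1)N1CC2CC(C1)N2`: 62%
Compound 3 `O=C(CC1C=CCC1)N1CC2CC(C1)N2`: 47%

In an assay on CHO cells for agonist activity at Neuronal acetylcholine receptor; alpha3/alpha6/beta2/beta3 (Homo sapiens), read by FLIPR and calcium flux (on this read-out lower numbers stand for smaller maximal responses and higher numbers for larger maximal responses), compound 1 gives 45%, the lowest of the three numbers. Compound 3 sits close to it, within the usual scatter, so the two cannot be told apart; compound 2 stands clearly higher, beyond the scatter. The next compound, compound 4 `O=C([C@H]1C[C@@H]1F)N1CC2CC(C1)N2`, has not yet been measured. Compared with compound 1 the change is 2-fluorocyclopropyl in place of isopropyl on a carbonyl carbon. Going by the values given here, no measured pair shares this kind of change, so there is no measured step to lean on. Since compound 2 gives 62% while compound 3 gives 47%, a small rise in this assay is expected, one that may well stay within the scatter. Compound 4 is therefore estimated at 50%, with a range from 35% to 65%, meaning an expected step of a number 5 percentage points higher from compound 1 to compound 4 (within the scatter).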

Compound 4, largest response reached (Emax), in percent of the reference or control that the assay uses: 85%
Compound 4: the middle estimate sits 35 percentage points below what was measured, outside the stated range (above it).
By their numbers in this assay, from the lowest: compounds 1 and 3 (each within the scatter of the next); then compound 2; then compound 4.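

In this assay, going by these compounds alone, putting 2-fluorocyclopropyl in place of isopropyl on a carbonyl carbon gives a large rise, a number 40 percentage points higher from compound 1 to compound 4 (beyond the scatter), and this is the first step measured at this position. Within the data shown here, it shows that the group on this carbonyl carbon can shift the maximal response strongly, a reach the earlier compounds did not reveal. Nothing measured here explains the rise.

Going by these compounds, whether the fluorine or the three-membered ring matters more stays open, and a plain cyclopropyl group would separate the two. On these data alone, the effect of the opposite arrangement at the two stereocentres also remains open.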